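The compounds below may be only part of what the source reports. "The series", "measured", "known", "first", "only" and "open" are said of these compounds alone.

Of the compounds shown here, three have so far been measured for how tightly they bind the receptor. In an assay on isolated protein for binding affinity to Type-2 angiotensin II receptor (Homo sapiens) (on this read-out lower numbers stand for stronger inhibition and higher numbers for weaker inhibition), compound 1 `CCCCN(CCCC)C(=O)CCCOC(=O)c1c(CC)nc(CCC)n1Cc1ccc(-c2ccccc2-c2nn[nH]n2)cc1` gives 500 nM, compound 2 `CCCOC(=O)NS(=O)(=O)c1ccccc1-c1ccc(Cn2c(CCC)nc(CC)c2C(=O)OCc2cccc(C(=O)c3ccccc3)c2)c(F)c1` gives 10 nM, and compound 3 `CCCc1nc(CC)c(C(=O)OCc2ccccc2OCCC(C)C)n1Cc1ccc(-c2ccccc2S(=O)(=O)NC(=O)OCCC(C)C)cc1F` gives 10 nM. Compound 3 thus sits level with compound 2 at the digits shown, the two together giving the lowest numbers, while compound 1 stands a good deal higher, a gap that lies well beyond the scatter. Compound 4 `CCCc1nc(CC)c(C(=O)OCc2ccccc2-c2ccccc2)n1Cc1ccc(-c2ccccc2S(=O)(=O)NC(=O)OCCC(C)C)cc1F` has not yet been measured; it differs from compound 3 by phenyl in place of isopentyloxy on an aromatic carbon. For the measured compounds named here, no step between two measured compounds that differ in a single place is on hand, so there is little to lean on. In this assay the step from compound 3 to compound 4 is expected to be about a 1.5-fold higher number from compound 3 to compound 4 (0.18 log units; within the scatter), within the scatter. Compound 4 is estimated at 15 nM, within a range from 4 nM to 60 nM.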

Compound 4, half-maximal inhibitory concentration: 9 nM
Estimate against measurement, compound 4: 1.7-fold (0.22 log units) above; measured number inside the range.
By their numbers in this assay, from the lowest: compounds 4, 2 and 3 (each within the scatter of the next); then compound 1.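

Putting phenyl in place of isopentyloxy on this aromatic carbon gives a 1.1-fold lower number from compound 3 to compound 4 (0.05 log units; within the scatter) in this assay. At this position, then, a ring of carbon only can replace an open chain holding an oxygen with no change beyond the scatter, so that oxygen's hydrogen-bond acceptor is not required for this level of binding in this pair. No measurement on hand explains why the two groups match. Still open, going by these compounds, is how a small methyl, an amine or a carboxylic acid would fare on this carbon. Also open, on these data alone, is whether the same swap would match on a different core.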